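The source may report more compounds than this note shows. Statements on the series, on what has been measured and on what is new or still open speak of the compounds shown alone.

In a functional assay on JAR cells (Homo sapiens) for inhibition, read by MTT assay, with a stated time of 72 h, tested at 10 uM (a higher number here means more inhibition at the concentration tested (going by the name of the read-out), a lower number less inhibition), compound 1 `CCOC(=O)C1=C(Nc2ccccc2)S/C(=C\c2ccccc2)C1=O` gives 20.3%, the lowest of the two numbers in hand. Compound 2 `CCOC(=O)C1=C(Nc2cccc(F)c2)S/C(=C\c2ccc[nH]2)C1=O` gives 45.4% in this assay. Compound 3 `CCOC(=O)C1=C(Nc2ccc(CC)cc2)S/C(=C\c2ccc[nH]2)C1=O` reaches only a limit of this assay, < 10%, not a number (the limit of < 10% in this assay, at which 1 of the 3 values shown sits). Among the compounds with values here, the one step measured in a single place, a number at least 35.4 percentage points lower from compound 2 to compound 3 (beyond the scatter), concerns the amine side of the core and not the position changed here. Compound 4 `CCOC(=O)C1=C(Nc2ccccc2)S/C(=C\c2cc3cccnc3[nH]2)C1=O` differs from compound 1 at the double-bonded chain carbon: a group of 9 heavy atoms (7 carbon, 2 nitrogen; one five-membered aromatic ring with 1 hetero atom, one six-membered aromatic ring with 1 hetero atom) in place of a group of 6 heavy atoms (6 carbon; one six-membered aromatic ring of carbon only), on a double-bonded chain carbon bound to a double-bonded ring carbon. Within the data shown here, no measured step covers this position alone; compound 1 and compound 2 differ there and on the amine at once, so their values show only that the pyrrole-bearing compound 2 sits higher. Compound 4 is therefore expected to land somewhat higher than compound 1, a step of a number 9.7 percentage points higher from compound 1 to compound 4 (within the scatter), with wide uncertainty. The estimate for compound 4 in this assay is 30%, within a range from 10% to 55%.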

Compound 4, a percentage reported as inhibition, at one concentration (the size of the read-out at that concentration, not a potency): 54.3%
Beside the measured number, compound 4's estimate is 24.3 percentage points below it; measured number inside the range.
By their numbers in this assay, from the lowest: compound 1; then compounds 2 and 4 (each within the scatter of the next). At a limit, below all of these: compound 3.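

In this assay, within the data shown here, the step of a number 34 percentage points higher from compound 1 to compound 4 (beyond the scatter) is the first reading of the double-bonded chain carbon on its own, with the amine side unchanged. The change at this position alone is therefore large, a separation that the pair of compound 1 and compound 2 could not give, as they also differ on the amine. Nothing measured here speaks to the cause of this step.

From the compounds shown here alone, it remains open which part of the entering group carries the step, the five-membered ring or the six-membered ring, and whether an indole, with carbon in place of the six-membered ring's nitrogen, would read the same. Also open, going by these compounds, is whether the step holds with 3-fluorophenyl or 4-ethylphenyl on the amine nitrogen.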